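Quinolin-2-yl to quinolin-8-yl on a shared amide

This account rests on a few compounds, and the source may have more. Where it says the series, first, only, none or still open, it means among the compounds named here.

Compound 2 `O=C(NC[C@@H]1C[C@@H]2C=C[C@@H]1C2)NS(=O)(=O)N1CCC(CCNC(=O)c2ccc3ccccc3n2)CC1` is one of two measured members of a series of sulfamoyl ureas. In a functional assay on the whole organism (blood) with Rattus norvegicus as the target, with stated times of 24 h and 1 h, at a dose of 5 mg/kg by the intraperitoneal route (a higher number here means a stronger effect of the compound at the dose given, a lower number a weaker effect), compound 2 gives 21%, and compound 1 `Cc1ncccc1C(=O)NCCC1CCN(S(=O)(=O)NC(=O)NC[C@@H]2C[C@@H]3C=C[C@@H]2C3)CC1` gives 16%; the two numbers lie within the scatter of each other, so neither can be called stronger. Within the data shown here, the only measured step, a number 5 percentage points higher from compound 1 to compound 2 (within the scatter), concerns a different change than the one now followed. Compound 3 `O=C(NC[C@@H]1C[C@@H]2C=C[C@@H]1C2)NS(=O)(=O)N1CCC(CCNC(=O)c2cccc3cccnc23)CC1` differs from compound 2 by quinolin-8-yl in place of quinolin-2-yl on a carbonyl carbon. Among the measured compounds shown here, no measured step in this assay covers an exchange of this kind, so there is no direct guide to its size or direction. For the measured compounds named here, with the one step that exists lying within the scatter, the expectation for this assay is a change that also stays within the scatter, a number 1 percentage points lower from compound 2 to compound 3 (within the scatter). Compound 3 is therefore estimated at 20%, with a likely range from 5% to 36%.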

Compound 3, a percentage reported as activity, at one dose (the size of the read-out at that dose, not a potency): 34%
The estimate for compound 3 lay 14 percentage points below the measured number, and the stated range covers the measured number.
By their numbers in this assay, from the lowest: compounds 1 and 2 (each within the scatter of the next); then compound 3.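

Joining the same quinoline to the amide carbonyl through a different ring atom is the first change in this series to go beyond the scatter in this assay: a number 13 percentage points higher from compound 2 to compound 3 (beyond the scatter). Quinolin-8-yl also stands clear of 2-methylpyridin-3-yl, with a number 18 percentage points higher from compound 1 to compound 3 (beyond the scatter), while quinolin-2-yl stayed within the scatter of that group, so among these three compounds, having a quinoline is not enough on its own and the point of attachment matters. Nothing available here explains the difference between the two quinolines.

As far as these compounds go, it remains open whether the gain depends on the ring nitrogen of quinolin-8-yl, which naphthalen-1-yl, an all-carbon ring pair, could test. Quinolin-4-yl or quinolin-5-yl would show whether other attachment points on the quinoline give similar numbers.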